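Removing a Hydroxy Group from Compound 2

The source may report more compounds than this note shows. Statements on the series, on what has been measured and on what is new or still open speak of the compounds shown alone.

Of the compounds shown here, three have been tested in an ADME assay on MDCK cells (Canis lupus familiaris) for cytotoxicity; on this read-out lower numbers stand for higher toxicity in this test and higher numbers for lower toxicity in this test. Compound 1 `O=[N+]([O-])C1=NNc2ncnn2C1c1ccc(O)cc1O` gives 90000 nM, and compound 3 `O=[N+]([O-])C1=NNc2ncnn2C1c1c(O)cc(O)cc1O` gives 119000 nM. The change hydrogen in place of hydroxy on an aromatic carbon produced a 1.3-fold lower number from compound 3 to compound 1 (0.12 log units; within the scatter). Compound 2 `O=[N+]([O-])C1=CNc2ncnn2C1c1ccc(O)c(O)c1O` gives 405000 nM; the difference between its core and that of compound 3 is not broken down here. Compound 4 `O=[N+]([O-])C1=CNc2ncnn2C1c1ccc(O)cc1O` has not yet been measured in this assay. It comes from compound 2 by hydrogen in place of hydroxy on an aromatic carbon. For the measured compounds named here, this is the same kind of change as the one from compound 3 to compound 1, but the place differs: there the carbon was ortho to a large group and meta to two hydroxy groups, here it is ortho to two hydroxy groups and meta to a large group. Resting on a 1.3-fold lower number from compound 3 to compound 1 (0.12 log units; within the scatter), the expected step is a 1.3-fold lower number from compound 2 to compound 4 (0.10 log units; within the scatter), a modest one. Compound 4 is therefore estimated at 320000 nM, between 130000 nM and 750000 nM.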

Compound 4, half-maximal cytotoxic concentration: > 1080000 nM
Compound 4: a limit, no number; the forecaster's own chance of this, stated with the estimate: 10%; middle value at least 3.3-fold (0.52 log units) away from the limit.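

In this assay compound 4 gives > 1080000 nM, which is a limit of the assay and not a number. Putting hydrogen in place of hydroxy on an aromatic carbon gave an at least 2.6-fold higher number from compound 2 to compound 4 (0.42 log units; beyond the scatter), so the earlier step did not carry over from one core to the other in this assay: the same change on two cores in this assay, a 1.3-fold lower number (0.12 log units; within the scatter) from compound 3 to compound 1 and an at least 2.6-fold higher number (0.42 log units; beyond the scatter) from compound 2 to compound 4, at least 3.5-fold (0.54 log units) apart, beyond the scatter of two such steps This does not show why the two steps part, nor how large the new one is, and two pairs give no rule for the series.

The compounds shown leave open how the read-out would respond on either core if a methoxy group or an amine stood in place of the hydroxy group. Also open, from the compounds shown here alone, is whether hydrogen in place of hydroxy at another carbon of the aromatic ring of compound 2 would have the same outcome.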